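Swapping the Dichlorophenyl for a Dimethoxyphenyl in Compound 1

The source may report more compounds than this note shows. Statements on the series, on what has been measured and on what is new or still open speak of the compounds shown alone.

Measured so far:
compound 1 `COc1cc(-c2cc(/C=C/C(=O)c3ccc(Cl)c(Cl)c3)[nH]n2)cc(OC)c1OC`, 59%
compound 2 `COc1ccc(-c2cc(/C=C/C(=O)c3ccc(N)cc3)[nH]n2)cc1OC`, 24%
compound 3 `COc1ccc(-c2cc(/C=C/C(=O)c3cc(OC)c(OC)c(OC)c3)[nH]n2)cc1OC`, -23%

In a functional assay on NCI-H322M cells (Homo sapiens) for cytotoxicity, read by sulforhodamine B assay, with a stated time of 48 h, tested at 10 uM (a lower number here means a stronger effect, a higher number a weaker effect of the compound at the concentration tested), compound 1 gives the highest of the three numbers, that is, the weakest effect. Compound 2 lies below it by a margin beyond the scatter, and compound 3 lies lower still, far beyond the scatter. For the measured compounds named here, compounds 2 and 3 differ from compound 1 in more than one place, so no single step between measured compounds can be read off.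

Compound 4 `COc1ccc(C(=O)/C=C/c2cc(-c3cc(OC)c(OC)c(OC)c3)n[nH]2)cc1OC` is not yet measured. It differs from compound 1 in one place: 3,4-dimethoxyphenyl in place of 3,4-dichlorophenyl on a carbonyl carbon.

Going by the values given here, with no matching step available, the expectation rests on the spread of the three values. Both compounds whose carbonyl-side ring carries something other than the dichlorophenyl give clearly lower numbers, so a drop beyond the scatter is expected from compound 1 to compound 4, a number 44 percentage points lower from compound 1 to compound 4 (beyond the scatter). For compound 4 the estimate is 15%, with a range from -20% to 50%.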

Compound 4, a percentage reported as activity, at one concentration (the size of the read-out at that concentration, not a potency): -96%
The estimate for compound 4 lay 111 percentage points above the measured number; the whole stated range lies above it.
By their numbers in this assay, from the lowest: compound 4; then compound 3; then compound 2; then compound 1.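

In this assay, putting 3,4-dimethoxyphenyl in place of 3,4-dichlorophenyl on a carbonyl carbon gives a number 155 percentage points lower from compound 1 to compound 4 (beyond the scatter), a large step. For the compounds shown here, this is the first comparison here in which only one place changes, so it shows that this group alone, with the rest of compound 1 kept, can shift the read-out far beyond the usual scatter. Nothing available explains why this swap has such a large effect.

The compounds shown leave open whether the step comes from losing the two chlorines, gaining the two methoxy groups, or both, which a plain phenyl at this place could help separate. They also leave open how a single methoxy group or a carboxylic acid on this ring would compare, with the rest of compound 1 unchanged.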